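Sulfonamide to urea on the pyrrolidine amine nitrogen

The compounds below may be only part of what the source reports. "The series", "measured", "known", "first", "only" and "open" are said of these compounds alone.

Compound 1, `CC(=O)N(Cc1ccccc1-c1ccccc1)[C@H]1CCNC1`, in an assay on HEK293 cells for inhibition of sodium-dependent dopamine transporter (Homo sapiens); a lower number here means a stronger inhibitor, a higher number a weaker inhibitor: "not determined" (no result reported).
Compound 2, `CCS(=O)(=O)N(Cc1ccccc1-c1ccccc1)[C@H]1CCNC1`, in this assay: 2760 nM.

Compound 2 stands alone as far as numbers go: in this assay compound 2 gives 2760 nM, and compound 1 contributes no figure, so nothing can be said about how the two compare. Compound 3, `CN(C)C(=O)N(Cc1ccccc1-c1ccccc1)[C@H]1CCNC1`, is not yet measured. Compound 3 differs from compound 2 in one place: dimethylcarbamoyl in place of ethylsulfonyl on an amine nitrogen. Among the measured compounds shown here, no pair of measured compounds shows what such a swap does here, so the direction of the step rests on no measured precedent. For the measured compounds named here, with only the single value of compound 2 to lean on, the size of the step is expected to be modest and is taken as lying within the scatter of this assay, with the sign left open. The step expected from the sulfonamide of compound 2 to the urea of compound 3 is therefore given as a 1.1-fold higher number from compound 2 to compound 3 (0.04 log units; within the scatter). On that basis compound 3 is estimated at 3000 nM in this assay, with a range from 900 nM to 10000 nM.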

Compound 3, inhibition constant: 2970 nM
The estimate for compound 3 lay 1.0-fold (0.00 log units) above the measured number; the range from low to high includes it.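

In this assay, among the compounds shown here, replacing ethylsulfonyl with dimethylcarbamoyl on the amine nitrogen gives a 1.1-fold higher number from compound 2 to compound 3 (0.03 log units; within the scatter), the first step here that can be read from two measured values. At this position, the sulfonyl group of compound 2 is therefore not needed to keep the value in this range: the dimethylcarbamoyl group of compound 3 has the same count of heavy atoms but a different make-up, with one double bond outside aromatic rings and one hydrogen-bond acceptor in place of two of each, and the two values still lie within the scatter of each other. No measurement shown here explains why this exchange leaves the two values so close.

Compound 1 has no number, so the acetyl group on the same nitrogen cannot be compared with either of the other two, and a single step cannot show how far this tolerance extends. Going by these compounds, it remains open what a primary amine, a carboxylic acid or a longer chain in this place would do in this assay, and whether any such group would move the value beyond the scatter.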